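Benzyl for cyclohexyl on a shared pyrimidine-diaryl amide core

The compounds below may be only part of what the source reports. "The series", "measured", "known", "first", "only" and "open" are said of these compounds alone.

Three compounds built on one shared core were measured in an assay on HeLa cells for displacement of a labelled ligand from adenosine receptor A3 (Homo sapiens), read by fluorescence polarization, with a stated time of 30 min; a lower number here means a stronger inhibitor, a higher number a weaker inhibitor. Compound 1 `COc1ccc(-c2cc(NC(=O)CCC(=O)N(C)CC(=O)NC3CCCCC3)nc(-c3ccc(OC)cc3)n2)cc1` gives 52900 nM. Compound 2 `COc1ccc(-c2cc(NC(=O)CCC(=O)N(C)CC(=O)NCc3ccccc3)nc(-c3ccc(OC)cc3)n2)cc1` gives 35400 nM. Compound 3 `COc1ccc(-c2cc(NC(=O)COCC(=O)N(C)CC(=O)NC3CCCCC3)nc(-c3ccc(OC)cc3)n2)cc1` gives 23700 nM, the lowest of the three numbers; the difference between the core of compound 3 and the core of compound 1 is not broken down here.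

The step from compound 1 to compound 2 is benzyl in place of cyclohexyl on an amide-type nitrogen and made a 1.5-fold lower number from compound 1 to compound 2 (0.17 log units; within the scatter).

Compound 4 `COc1ccc(-c2cc(NC(=O)COCC(=O)N(C)CC(=O)NCc3ccccc3)nc(-c3ccc(OC)cc3)n2)cc1` has not been measured in this assay. It is related to compound 3 by benzyl in place of cyclohexyl on an amide-type nitrogen, the same change as between compound 1 and compound 2, made at the same kind of place. Because the earlier step was a 1.5-fold lower number from compound 1 to compound 2 (0.17 log units; within the scatter), the author expects a step of about the same size, a 1.4-fold lower number from compound 3 to compound 4 (0.14 log units; within the scatter), from compound 3 to compound 4, while noting that it rests on a single precedent. Compound 4 is therefore estimated to give 17000 nM in this assay, within a range from 8000 nM to 40000 nM.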

Compound 4, inhibition constant: 40100 nM
Beside the measured number, compound 4's estimate is 2.4-fold (0.37 log units) below it, outside the stated range (above it).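

In this assay, benzyl in place of cyclohexyl on an amide-type nitrogen gave a 1.7-fold higher number from compound 3 to compound 4 (0.23 log units; within the scatter), so the new step, like the earlier one, lies within the scatter. Set side by side, the two steps cannot be told apart: the same change on two cores in this assay, a 1.5-fold lower number (0.17 log units; within the scatter) from compound 1 to compound 2 and a 1.7-fold higher number (0.23 log units; within the scatter) from compound 3 to compound 4, 2.5-fold (0.40 log units) apart, within the scatter of two such steps. Among these compounds, this shows that the change made no step beyond the scatter on either of these two cores, but it does not show a real effect of fixed direction that carries from one core to the other, and with only two small steps, neither a transfer of such an effect nor a dependence on the core can be established.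

The compounds shown leave open whether another group on that amide-type nitrogen, such as phenethyl, an amine or a carboxylic acid, would give a step beyond the scatter. They also leave open whether the benzyl for cyclohexyl change would behave alike on a core with a longer chain.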